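Removing the Benzyl Group from Compound 2

The compounds below may be only part of what the source reports. "The series", "measured", "known", "first", "only" and "open" are said of these compounds alone.

In a functional assay on MDA-MB-231 cells (Homo sapiens) for cytotoxicity, read by MTT assay, with a stated time of 72 h (on this read-out higher numbers stand for weaker inhibition and lower numbers for stronger inhibition), compound 1 (`CCN(CC)Cc1ccc2nc(NC(=O)N/N=C/c3cn(Cc4cccc(Cl)c4)c4ccccc34)sc2c1`) gives 2050 nM, compound 2 (`CCN(CC)Cc1ccc2nc(NC(=O)N/N=C/c3cn(Cc4ccc(C)cc4)c4ccccc34)sc2c1`) gives 2010 nM and compound 3 (`Cc1ccc(Cn2cc(/C=N/NC(=O)Nc3nc4ccc(CN5CCC(C)CC5)cc4s3)c3ccccc32)cc1`) gives 1140 nM. Compound 2 thus stands among numbers that all lie within the scatter of its own. Compound 4 (`CCN(CC)Cc1ccc2nc(NC(=O)N/N=C/c3c[nH]c4ccccc34)sc2c1`) has hydrogen in place of 4-methylbenzyl on an aromatic nitrogen. Two measured steps offer some guidance. The nearer one, a 1.0-fold lower number from compound 1 to compound 2 (0.01 log units; within the scatter), exchanges 3-chlorophenyl for 4-methylphenyl on the same chain carbon and stays within the scatter, but the group remains in place. The other, a 1.8-fold lower number from compound 2 to compound 3 (0.25 log units; within the scatter), concerns a different part of the molecule and says little here. Going by the values given here, no measured compound lacks the group, so the expectation is uncertain and rests on the size of the loss. A higher number is expected, and the estimated change is a 2.5-fold higher number from compound 2 to compound 4 (0.40 log units; beyond the scatter). For compound 4 the estimated value is 5000 nM, with an expected range from 1800 nM to 15000 nM.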

Compound 4, half-maximal inhibitory concentration: 1900 nM
Beside the measured number, compound 4's estimate is 2.6-fold (0.42 log units) above it, and the stated range covers the measured number.
By their numbers in this assay, from the lowest: compounds 3, 4, 2 and 1 (each within the scatter of the next).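

In this assay, hydrogen in place of 4-methylbenzyl on the aromatic nitrogen gives a 1.1-fold lower number from compound 2 to compound 4 (0.02 log units; within the scatter) and hydrogen in place of 3-chlorobenzyl gives a 1.1-fold lower number from compound 1 to compound 4 (0.03 log units; within the scatter), so both steps lie within the scatter. The earlier compounds shown here only exchanged one benzyl group for another at this position, whereas compound 4 shows that, for compound 1 and compound 2, the entire group can leave without a step beyond the scatter. No measured information bears on why this is so.

The compounds shown leave open whether a methyl group, a longer chain ending in an amine, or a carboxylic acid on this nitrogen would give a step beyond the scatter. They also leave open whether hydrogen here would give the same result with the 4-methylpiperidin-1-yl group of compound 3.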